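The compounds below may be only part of what the source reports. "The series", "measured", "known", "first", "only" and "open" are said of these compounds alone.

Compound 1 `Cn1c(=O)c(S(=O)(=O)c2ccc(O)cc2)cc2cnc(Nc3ccc4[nH]ccc4c3)nc21` carries a 4-hydroxyphenyl group on its sulfonyl sulfur. Within the data shown here, in a functional assay on DU-145 cells (Homo sapiens) for inhibition, read by trypan blue exclusion, with a stated time of 72 h (a lower number here means a stronger inhibitor, a higher number a weaker inhibitor), compound 1 gives 250 nM, the lower of the two numbers measured so far. Compound 2 `O=c1c(S(=O)(=O)c2ccc(F)cc2F)cc2cnc(Nc3ccc4[nH]ccc4c3)nc2n1CC1CCCC1` differs from it in more than one place, and in this assay compound 2 gives 10000 nM, a gap well beyond the scatter. Compound 3 `Cn1c(=O)c(S(=O)(=O)c2ccc(N)cc2F)cc2cnc(Nc3ccc4[nH]ccc4c3)nc21` is not yet measured; it differs from compound 1 by 4-amino-2-fluorophenyl in place of 4-hydroxyphenyl on a sulfonyl sulfur. Among the measured compounds shown here, no measured pair isolates this change, so the step of a 1.6-fold higher number from compound 1 to compound 3 (0.20 log units; within the scatter) is expected to be small, probably within the scatter, with at most a slight drift toward a higher number. Compound 3 is therefore estimated at 400 nM, within a range of 100 nM to 1500 nM.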

Compound 3, half-maximal inhibitory concentration: 8000 nM
Compound 3: the middle estimate sits 20-fold (1.30 log units) below what was measured; the whole stated range lies below it.
By their numbers in this assay, from the lowest: compound 1; then compounds 3 and 2 (each within the scatter of the next).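

In this assay, placing 4-amino-2-fluorophenyl on the sulfonyl sulfur instead of 4-hydroxyphenyl gives a 32-fold higher number from compound 1 to compound 3 (1.51 log units; beyond the scatter), so the choice of aromatic group at this place matters greatly. The earlier comparison, between compounds differing in more than one place, could not show this. Here the rest of the molecule stays the same, and the large step follows this single exchange.

From the compounds shown here alone, whether the amino group, the fluorine or the loss of the hydroxyl drives the step stays open, and a 4-aminophenyl group on the same sulfur would help separate them. Nothing available gives a measured reason for the step.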